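The compounds below may be only part of what the source reports. "The series", "measured", "known", "first", "only" and "open" are said of these compounds alone.

Compound 1 `CCN(C)c1nc(Cc2c(F)cccc2F)cc(=O)[nH]1` is the reference of this set. In an ADME assay on MT4 cells (Homo sapiens) for cytotoxicity, read by MTT assay, with a stated time of 4 days (on this read-out higher numbers stand for lower toxicity in this test and lower numbers for higher toxicity in this test), compound 1 gives > 89000 nM, which is a limit of the assay rather than a number. Compound 2 `CCCN(C)c1nc(Cc2c(F)cccc2F)cc(=O)[nH]1` gives 85000 nM in this assay. Compound 3 `CCCN(CCC)c1nc(Cc2c(F)cccc2F)cc(=O)[nH]1` gives > 78000 nM, again a limit. The measured steps are an at least 1.0-fold lower number from compound 1 to compound 2 (0.01 log units; that floor lies within the scatter), a step that the two limits leave unreadable from compound 1 to compound 3 and a step that the limit leaves unreadable from compound 2 to compound 3; none shows a readable change, and the values sit at the limits recorded in the limit of > 78000 nM in this assay, at which 1 of the 3 values shown sits, and (the limit of > 89000 nM in this assay, at which 1 of the 3 values shown sits). Compound 4 `CC1CCN(c2nc(Cc3c(F)cccc3F)cc(=O)[nH]2)CC1` carries 4-methylpiperidin-1-yl in place of ethyl(methyl)amino on an aromatic carbon. The nearest measured change, a step that the two limits leave unreadable from compound 1 to compound 3, gives no readable step, and no shift beyond the scatter is expected in this assay. Compound 4 is therefore expected at 85000 nM, between 40000 nM and 160000 nM, which means an expected at least 1.0-fold lower number from compound 1 to compound 4 (0.01 log units; that floor lies within the scatter).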

Compound 4, half-maximal cytotoxic concentration: > 78000 nM
Compound 4 gave a limit, no number; the forecaster's own chance of this, stated with the estimate: 60%; the middle value lies beyond the limit too.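

Compound 4 gives > 78000 nM, a limit and not a number, so its steps to compound 1, compound 2 and compound 3 cannot be read. The compounds shown leave open whether changing this amino group shifts the read-out in this assay at all.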